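Compound 3 and its 4-acetoxyphenyl counterpart

The compounds below may be only part of what the source reports. "The series", "measured", "known", "first", "only" and "open" are said of these compounds alone.

In a functional assay on DU-145 cells (Homo sapiens) for inhibition, read by trypan blue exclusion, with a stated time of 96 h (a lower number here means a stronger inhibitor of growth, a higher number a weaker inhibitor of growth), compound 1 (`Cc1ccc(S(=O)(=O)/C(=C/c2ccc(O)c([N+](=O)[O-])c2)C(=O)c2ccc(Cl)cc2)cc1`) gives 25000 nM while compound 2 (`Cc1ccc(S(=O)(=O)/C(=C/c2ccc(Cl)cc2)C(=O)c2ccc(Cl)cc2)cc1`) gives 1000 nM and compound 3 (`COc1ccc(/C=C(\C(=O)c2ccc(Cl)cc2)S(=O)(=O)c2ccc(C)cc2)cc1O`) gives 1000 nM as well. Compound 3 therefore shares the lowest of the three numbers with compound 2. Compound 4 (`CC(=O)Oc1ccc(/C=C(\C(=O)c2ccc(Cl)cc2)S(=O)(=O)c2ccc(C)cc2)cc1`) is still unmeasured and departs from compound 3 on a double-bonded chain carbon bound to a double-bonded chain carbon, with 4-acetoxyphenyl in place of 3-hydroxy-4-methoxyphenyl (4-acetoxyphenyl in place of 3-hydroxy-4-methoxyphenyl on a double-bonded chain carbon bound to a double-bonded chain carbon). Going by the values given here, all the measured steps concern this same place. Both steps away from the 4-hydroxy-3-nitrophenyl group of compound 1 were large (a 25-fold lower number from compound 1 to compound 2 (1.40 log units; beyond the scatter) and a 25-fold lower number from compound 1 to compound 3 (1.40 log units; beyond the scatter)). Exchanging 4-chlorophenyl for 3-hydroxy-4-methoxyphenyl gave no change at the digits printed from compound 2 to compound 3 (within the scatter) instead. The incoming group is neither of these, and three compounds support no rule, so the expectation is only that it behaves like the two groups with the lower numbers, perhaps with a slightly higher number. The step expected in this assay is a 1.5-fold higher number from compound 3 to compound 4 (0.18 log units; within the scatter) and would stay within the scatter. Compound 4 is estimated at 1500 nM (400 nM to 6000 nM).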

Compound 4, concentration for 50% growth inhibition: 25000 nM
The estimate for compound 4 lay 17-fold (1.22 log units) below the measured number; the whole stated range lies below it.
By their numbers in this assay, from the lowest: compounds 2 and 3 (each within the scatter of the next); then compounds 1 and 4 (each within the scatter of the next).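

In this assay, the change at this position gives a 25-fold higher number from compound 3 to compound 4 (1.40 log units; beyond the scatter) and also a 25-fold higher number from compound 2 to compound 4 (1.40 log units; beyond the scatter) with acetoxy in place of chloro on an aromatic carbon, so a high number is no longer confined to the 4-hydroxy-3-nitrophenyl group of compound 1. The 4-acetoxyphenyl group instead joins that group, with no change at the digits printed from compound 1 to compound 4 (within the scatter) and thus the two compounds level at the digits printed, while the 4-chlorophenyl and 3-hydroxy-4-methoxyphenyl groups remain together at the lower number. Nothing available here accounts for this split between the two pairs.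

The compounds shown leave open which part of the 4-acetoxyphenyl group carries the step, since the 3-hydroxy-4-methoxyphenyl group differs from it in more than one feature. They also leave open whether a 4-hydroxyphenyl or 4-aminophenyl group on this carbon would side with compound 3 or with compound 4.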